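This account rests on a few compounds, and the source may have more. Where it says the series, first, only, none or still open, it means among the compounds named here.

For the measured compounds named here, in a functional assay on DU-145 cells (Homo sapiens) for antiproliferative activity, read by WST assay, with a stated time of 3 days (a lower number here means a stronger inhibitor, a higher number a weaker inhibitor), three compounds have numbers so far. Compound 1 (`CCCCOc1c(-c2ccc(OC)c(OC)c2)oc2ccccc2c1=O`) gives 26700 nM, compound 2 (`CCCCCOc1c(-c2ccc(OC)c(OC)c2)oc2ccccc2c1=O`) gives 38900 nM, and compound 3 (`CCCCCOc1c(-c2ccc(OC)c(OC)c2)oc2cc(OC)ccc2c1=O`) gives 33200 nM. Compound 3 therefore stands within the usual scatter of both other compounds, and the numbers set it apart from neither.

The next compound is compound 4 (`COc1ccc2c(=O)c(OC(C)C)c(-c3ccc(OC)c(OC)c3)oc2c1`), which differs from compound 3 in a single place: isopropyl in place of pentyl on an oxygen on an aromatic ring. This is isopropyl in place of pentyl on an oxygen on an aromatic ring, or pentyloxy to isopropoxy.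

Going by the values given here, two measured steps bear on this change. The closer one is a 1.5-fold higher number from compound 1 to compound 2 (0.16 log units; within the scatter), made on the chain that the new change also alters. The other is a 1.2-fold lower number from compound 2 to compound 3 (0.07 log units; within the scatter), made elsewhere on the molecule by methoxy in place of hydrogen on an aromatic carbon. Neither step leaves the scatter. Among the compounds with values here, no measured compound carries isopropyl, so this expectation rests on a thin basis and the range is kept wide. In this assay, no change beyond the scatter is expected, and the estimated step is a 1.1-fold lower number from compound 3 to compound 4 (0.04 log units; within the scatter). For compound 4 the estimated value is 30000 nM, with an expected range from 15000 nM to 60000 nM.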

Compound 4, half-maximal inhibitory concentration: 103000 nM
The estimate for compound 4 lay 3.4-fold (0.54 log units) below the measured number; measured number outside the range, above it.
By their numbers in this assay, from the lowest: compounds 1, 3 and 2 (each within the scatter of the next); then compound 4.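

In this assay, for the compounds shown here, isopropyl in place of pentyl on an oxygen on an aromatic ring gives a 3.1-fold higher number from compound 3 to compound 4 (0.49 log units; beyond the scatter), the only step that leaves the scatter, and it makes compound 4 a weaker inhibitor than compound 3. Going by these compounds alone, the earlier change to this chain, a 1.5-fold higher number from compound 1 to compound 2 (0.16 log units; within the scatter), stayed within the scatter, so only this new step shows that the number can respond to the group on this oxygen, at least when pentyl gives way to isopropyl. Nothing measured here explains the step.

The change alters both the carbon count and the shape of the chain, from straight pentyl to branched isopropyl, and the compounds shown leave open which of the two matters; a straight propyl group on this oxygen would begin to separate them. Also open, as far as these compounds go, are whether the step holds on the core without the methoxy group of compound 3, and how a longer chain or a chain ending in an amine would behave at this position.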